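Naphthyl semicarbazones in a seizure model: trimming a methoxy

This account rests on a few compounds, and the source may have more. Where it says the series, first, only, none or still open, it means among the compounds named here.

Compound 1 `O=C(N/N=C/c1ccc(Cl)cc1Cl)Nc1cccc2ccccc12`: 100 mg/kg
Compound 2 `O=C(N/N=C/c1ccccc1[N+](=O)[O-])Nc1cccc2ccccc12`: 300 mg/kg
Compound 3 `COc1cc(/C=N/NC(=O)Nc2cccc3ccccc23)cc(OC)c1OC`: 100 mg/kg

Three semicarbazones built on a shared core were tested in a functional assay on the whole organism (strain Swiss albino) with Mus musculus as the target, in the maximal electroshock model, with a stated time of 4 h; a higher number here means that more compound is needed for the effect, a lower number that less compound is needed. Compound 1 gives 100 mg/kg and compound 3 gives 100 mg/kg in this assay, the two values level at the digits printed and together the lowest of the three numbers; compound 2 gives 300 mg/kg, a higher number than compound 3 that lies beyond the usual scatter.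

Compound 4 `COc1ccc(/C=N/NC(=O)Nc2cccc3ccccc23)cc1OC` has not yet been measured in this assay. Its structure differs from compound 3 in one place: hydrogen in place of methoxy on an aromatic carbon. The two remaining methoxy groups are kept.

Going by the values given here, no step between two measured compounds that differ in one place is available, so the effect of removing one methoxy group cannot be read from the data at hand. Given that compound 1 and compound 3, with quite different substitution on the benzylidene ring, return the same number in this assay, the expected change is small. Compound 4 is expected to give about 100 mg/kg in this assay, within a range of 50 mg/kg to 300 mg/kg, which corresponds to an expected step of no change at the digits printed from compound 3 to compound 4 (within the scatter).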

Compound 4, minimum effective dose: 100 mg/kg
Compound 4: middle estimate and measured number agree at the digits printed, within the range that was stated.
By their numbers in this assay, from the lowest: compounds 1, 3 and 4 (each within the scatter of the next); then compound 2.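

Going by these compounds alone, the first step between two compounds that differ in one place comes from this pair: in this assay hydrogen in place of methoxy on an aromatic carbon gives no change at the digits printed from compound 3 to compound 4 (within the scatter) and so gives the series its first direct reading of a single change. The earlier compounds shown here could show only that different substitution on the ring can return similar numbers, whereas this step isolates one methoxy group, ortho to a methoxy group and meta to a large group. With the two remaining methoxy groups kept, the minimum effective dose does not depend on the presence of this methoxy group, and no measurement at hand explains why this is so.

From the compounds shown here alone, it remains open whether this position accepts other groups equally, since only methoxy and hydrogen have been seen there, and a hydroxyl group, an amine or a longer chain such as ethoxy might give a different reading. It is also open whether taking away either of the two remaining methoxy groups would leave the number where it stands, as no step at those places can be read from the compounds shown.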